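Replacing the Tetrazolylmethyl Group in an EP3 Antagonist Series

The source may report more compounds than this note shows. Statements on the series, on what has been measured and on what is new or still open speak of the compounds shown alone.

Measured so far, in a functional assay on CHO cells for antagonist activity at prostaglandin E2 receptor EP3 subtype (Homo sapiens), read by cAMP accumulation; a higher number here means a weaker inhibitor, a lower number a stronger inhibitor:
compound 1 `CC(C)C(c1ccc(-c2ccc3cccc(F)c3c2)[nH]c1=O)N1CCCCC1=O` — 40 nM
compound 2 `CC(C)C(Cc1nnn[nH]1)c1ccc(-c2ccc3cccc(F)c3c2)[nH]c1=O` — 134 nM

Going by the values given here, compound 2 gives the highest of the two numbers in this assay, and so is the weaker of the two measured inhibitors; compound 1 is its only neighbour, and the change a 3.4-fold higher number from compound 1 to compound 2 (0.53 log units; beyond the scatter) lies beyond the usual scatter.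

Compound 3 `CC(C)C(/C=C1/CCNC1=O)c1ccc(-c2ccc3cccc(F)c3c2)[nH]c1=O` is not yet measured. It differs from compound 2 in one place: a group of 7 heavy atoms (5 carbon, 1 nitrogen, 1 oxygen; one five-membered non-aromatic ring with 1 hetero atom) in place of a group of 6 heavy atoms (2 carbon, 4 nitrogen; one five-membered aromatic ring with 4 hetero atoms), on a saturated chain carbon bound to an aromatic carbon and a saturated chain carbon. The group that enters carries a five-membered non-aromatic ring with one hetero atom, one hydrogen-bond donor and one hydrogen-bond acceptor, which makes it more like the 2-oxopiperidin-1-yl group of compound 1 than like the tetrazole of compound 2.

Among the compounds with values here, only one measured step bears on this: a 3.4-fold higher number from compound 1 to compound 2 (0.53 log units; beyond the scatter), where the tetrazolylmethyl group replaced a ring of the same broad kind as the one now entering. Undoing that direction suggests a modest move back toward a lower number in this assay. Compound 3 is therefore expected to show a 2.2-fold lower number from compound 2 to compound 3 (0.35 log units; beyond the scatter), with an estimate of 60 nM and a plausible range from 20 nM to 200 nM.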

Compound 3, half-maximal inhibitory concentration: 8.1 nM
Beside the measured number, compound 3's estimate is 7.4-fold (0.87 log units) above it; measured number below the stated range.
By their numbers in this assay, from the lowest: compound 3; then compound 1; then compound 2.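

In this assay, the place on a saturated chain carbon bound to an aromatic carbon and a saturated chain carbon proves far more sensitive than the first pair suggested: putting the group with the five-membered non-aromatic ring where (1H-tetrazol-5-yl)methyl stood gives a 17-fold lower number from compound 2 to compound 3 (1.22 log units; beyond the scatter), a large step. The new group does more than recover the ground lost with the tetrazole, since it also outdoes the 2-oxopiperidin-1-yl group of compound 1 with a 4.9-fold lower number from compound 1 to compound 3 (0.69 log units; beyond the scatter), and this makes compound 3 the strongest inhibitor of the three. No measurement in hand explains this gain.

Compound 1 and compound 3 differ in ring size and also in the double bonds outside aromatic rings that only compound 3 carries, so the share of each in the gain stays unresolved, and a version of compound 3 with a saturated chain and the same five-membered ring would help separate them. Also open, as far as these compounds go, is how this place would respond to a carboxylic acid or an amine, groups unlike any of the three seen here.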